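Stability of a Carbamate Variant in Mouse Liver Microsomes

This account rests on a few compounds, and the source may have more. Where it says the series, first, only, none or still open, it means among the compounds named here.

Compound 1 `COc1cc(-c2c(C)nc3c(N4CC[C@@H](NC(C)=O)C4)cc(C)nn23)cc(OC)c1OC`: > 95%
Compound 2 `CC(=O)N[C@@H]1CCN(c2cc(C)nn3c(-c4cccc(S(=O)(=O)N(C)C)c4)c(C)nc23)C1`: > 95%
Compound 3 `COc1ccc(-c2c(C)nc3c(N4CC[C@@H](NC(=O)c5ccccc5)C4)cc(C)nn23)cc1OC`: > 95%

In an ADME assay on microsomes from liver (Mus musculus) for metabolic stability, read by LC-MS, with NADPH named in the record, with a stated time of 60 min, tested at 1 uM, in the absence of a further agent (on this read-out higher numbers stand for a more stable compound and lower numbers for a less stable compound), compound 1 gives > 95%, which is a limit of the assay rather than a number. Compound 2 gives > 95% in this assay, again a limit. Compound 3 gives > 95% in this assay, also a limit. Compound 3 therefore stands where every measured compound stands, at the limit of > 95% in this assay, at which 3 of the 3 values shown sit. Within the data shown here, since no two measured compounds differ in only one place, no measured step exists to guide the next comparison.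

Compound 4 `COc1ccc(-c2c(C)nc3c(N4CC[C@@H](NC(=O)Oc5ccc6ccccc6c5)C4)cc(C)nn23)cc1OC` differs from compound 3 in one place: (naphthalen-2-yl)oxy in place of phenyl on a carbonyl carbon. Nothing measured here shows what this change does to stability. I expect a modest step downward, a number at least 13 percentage points lower from compound 3 to compound 4 (beyond the scatter), with a fair chance that the result is again only a limit because every value so far sits at the limit of > 95% in this assay, at which 3 of the 3 values shown sit. Compound 4 is expected to give about 82%, between 55% and 98%.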

Compound 4, percent of the compound remaining: > 95%
Compound 4: a limit, no number; the forecaster's own chance of this, stated with the estimate: 40%; middle value at least 13 percentage points from the limit.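

In this assay compound 4 gives > 95%, a limit and not a number. Among these compounds, compound 3 also sits at a limit, so no step from it to compound 4 can be read. The compounds shown leave open whether any of these changes alters stability, because every value sits at one limit: the limit of > 95% in this assay, at which 4 of the 4 values shown sit.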